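A few compounds are considered here, and "the series" means these few. Any claim that something is new, unique, unknown or untested is made for them only; others in the source may bear on it.

Compound 2, `OCC#CCSc1cnc2ccccc2c1SCC#CCO`, gives 32 ug/mL in a functional assay on SW707 cells (Homo sapiens) for cytotoxicity, read by sulforhodamine B assay, with a stated time of 72 h; a lower number here means a stronger inhibitor, a higher number a weaker inhibitor. Among the three compounds measured it stands second highest: compound 1, `OCC#CCSc1cnc2ccccc2c1[Se]CC#CCO`, gives 26.6 ug/mL, and the step of a 1.2-fold higher number from compound 1 to compound 2 (0.08 log units; within the scatter); compound 3, `COc1c(SCC#CCO)cnc2ccccc12`, gives 67.4 ug/mL, and the step of a 2.1-fold higher number from compound 2 to compound 3 (0.32 log units; beyond the scatter).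

Compound 4, `C#CCSc1cnc2ccccc2c1SCC#CCO`, has not yet been measured. It differs from compound 2 in one place: hydrogen in place of hydroxymethyl on a triple-bonded carbon. Going by the values given here, none of the measured steps touches the end of this chain; each of them exchanges a whole side group on an aromatic carbon for another, and the one that replaced a six-atom group with a two-atom group, a 2.1-fold higher number from compound 2 to compound 3 (0.32 log units; beyond the scatter), is a different kind of change. The data therefore give no direct guide for the loss of the hydroxymethyl. With only a hydrogen entering, the step of a 1.3-fold higher number from compound 2 to compound 4 (0.10 log units; within the scatter) is expected to be small, most likely within the scatter, leaning if anything toward a higher number. Compound 4 is accordingly estimated at 40 ug/mL, with a range from 18 ug/mL to 90 ug/mL in this assay.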

Compound 4, concentration for 50% inhibition: 42.6 ug/mL
For compound 4 the middle estimate is 1.1-fold (0.03 log units) below the measured one; measured number inside the range.
By their numbers in this assay, from the lowest: compounds 1, 2, 4 and 3 (each within the scatter of the next, the first and the last beyond it).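

Going by these compounds alone, the step of a 1.3-fold higher number from compound 2 to compound 4 (0.12 log units; within the scatter) is the first measured change at the end of a chain rather than an exchange of a whole side group on an aromatic carbon. It shows that in this assay hydroxymethyl on this triple-bonded carbon can give way to hydrogen with no shift beyond the scatter, so that 4-hydroxybut-2-yn-1-yl can become propargyl on the shared core while the other chain stays as it is. Nothing measured here accounts for this result.

What the compounds shown leave open is how an amine, a carboxylic acid or a longer chain would read on this triple-bonded carbon. They also leave open whether the same exchange would read alike on the other chain, or on compound 1 with its selenium.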